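Changing the Amide Group on a Shared Core

The compounds below may be only part of what the source reports. "The series", "measured", "known", "first", "only" and "open" are said of these compounds alone.

Three compounds have been measured in a functional assay on A549 cells (Homo sapiens) for inhibition, read by sulforhodamine B assay, with a stated time of 72 h; on this read-out higher numbers stand for weaker inhibition and lower numbers for stronger inhibition:

Compound 1, `Nc1sc(-c2ccc(Cl)cc2)c(-c2ccc(Cl)cc2)c1C(=O)NC1CCCCC1`, gives 2410 nM.
Compound 2, `CC1CCN(C(=O)c2c(N)sc(-c3ccc(Cl)cc3)c2-c2ccc(Cl)cc2)CC1`, gives 1750 nM.
Compound 3, `Nc1sc(-c2ccc(Cl)cc2)c(-c2ccc(Cl)cc2)c1C(=O)NC1CCC1`, gives 12500 nM.

Compound 2 has the lowest of the three numbers in this assay. Its nearest neighbour is compound 1, with a 1.4-fold lower number from compound 1 to compound 2 (0.14 log units; within the scatter), so these two cannot be ranked against each other. Compound 3 is clearly apart: a 7.1-fold higher number from compound 2 to compound 3 (0.85 log units; beyond the scatter).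

Compound 4, `COc1ccc(CNC(=O)c2c(N)sc(-c3ccc(Cl)cc3)c2-c2ccc(Cl)cc2)cc1`, is the next step from compound 2. The change is (4-methoxybenzyl)amino in place of 4-methylpiperidin-1-yl on a carbonyl carbon. Two kinds of measured step bear on it. The first, a 1.4-fold lower number from compound 1 to compound 2 (0.14 log units; within the scatter), shows that exchanging a cyclohexylamino for a 4-methylpiperidin-1-yl on the carbonyl carbon left the number essentially unchanged. The second, a 5.2-fold higher number from compound 1 to compound 3 (0.71 log units; beyond the scatter) and a 7.1-fold higher number from compound 2 to compound 3 (0.85 log units; beyond the scatter), shows that a smaller cyclobutyl group on the amide-type nitrogen gave a modestly higher number. For the measured compounds named here, the incoming (4-methoxybenzyl)amino is larger than either ring and, like compound 1, carries one hydrogen-bond donor; no measured step covers an aromatic ring or a methoxy group at this position.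

For compound 4 the expected step is a 1.4-fold higher number from compound 2 to compound 4 (0.15 log units; within the scatter), small and uncertain in direction. The estimate for compound 4 is 2500 nM, within 800 nM to 8000 nM.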

Compound 4, half-maximal inhibitory concentration: 18200 nM
Compound 4: middle estimate off by 7.3-fold (0.86 log units), on the low side, outside the stated range (above it).
By their numbers in this assay, from the lowest: compounds 2 and 1 (each within the scatter of the next); then compounds 3 and 4 (each within the scatter of the next).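

In this assay the (4-methoxybenzyl)amino group on the carbonyl carbon brings a large rise (a 10-fold higher number from compound 2 to compound 4 (1.02 log units; beyond the scatter)), which shows that this position does not take every change as quietly as the exchange between cyclohexylamino and 4-methylpiperidin-1-yl. On the amide-type nitrogen, 4-methoxybenzyl in place of cyclohexyl also gives a clearly higher number (a 7.6-fold higher number from compound 1 to compound 4 (0.88 log units; beyond the scatter)), while the comparison with the cyclobutyl amide (a 1.5-fold higher number from compound 3 to compound 4 (0.16 log units; within the scatter)) shows that these two very different groups cannot be ranked against each other, so among the four compounds both cyclobutyl and 4-methoxybenzyl sit apart from the pair holding cyclohexyl and 4-methylpiperidin-1-yl. Nothing available here explains why the number rises with this group.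

Going by these compounds, it remains open whether the rise belongs to the methoxy group or to the benzyl part, which a plain benzyl group on the same nitrogen would help to separate. On these data alone, it is also open how the position would respond to a simple dimethylamino group, or to a longer chain such as hexyl that carries no ring at all.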